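Swapping phenyl for 1,3-thiazol-4-yl in compound 2

This account rests on a few compounds, and the source may have more. Where it says the series, first, only, none or still open, it means among the compounds named here.

Values measured in an in vitro ADME assay on microsomes from liver (Homo sapiens) for metabolic stability (a lower number here means slower removal, a higher number faster removal of the compound), are these
- compound 1 `O=C(COCc1ccccc1)N1CCN(c2cccc(Cl)c2)CC1` gives 310 mL.min-1.g-1
- compound 2 `O=C(COCc1ccccc1)N1CCN(c2ccc(Cl)cc2Cl)CC1` gives 450 mL.min-1.g-1
- compound 3 `O=C(COCc1ccccc1)N1CCN(c2ccc(F)cc2F)CC1` gives 580 mL.min-1.g-1

Compound 2 stands at 450 mL.min-1.g-1 and cannot be told apart from the other two, since a 1.5-fold higher number from compound 1 to compound 2 (0.16 log units; within the scatter) and a 1.3-fold higher number from compound 2 to compound 3 (0.11 log units; within the scatter) are small steps.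

The next compound is compound 4 `O=C(COCc1cscn1)N1CCN(c2ccc(Cl)cc2Cl)CC1`, not yet measured. It differs from compound 2 by one exchange (1,3-thiazol-4-yl in place of phenyl on a saturated chain carbon bound to an oxygen on a saturated carbon), with 1,3-thiazol-4-yl in place of phenyl on a saturated chain carbon bound to an oxygen on a saturated carbon.

The measured steps, such as a 1.9-fold higher number from compound 1 to compound 3 (0.27 log units; within the scatter), only swap the group on an amine nitrogen in a ring. None touches this place, so the data give no direct size for the exchange. A small step towards a lower number in this assay is expected, possibly not beyond the scatter, and this expectation is uncertain. The estimated step is a 1.7-fold lower number from compound 2 to compound 4 (0.22 log units; within the scatter) as a best guess. For compound 4 the expected value is 270 mL.min-1.g-1, with an estimated range from 110 mL.min-1.g-1 to 560 mL.min-1.g-1 as its bounds.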

Compound 4, intrinsic clearance in microsomes: 62 mL.min-1.g-1
The estimate for compound 4 lay 4.4-fold (0.64 log units) above the measured number, and the stated range ends above it.
By their numbers in this assay, from the lowest: compound 4; then compounds 1, 2 and 3 (each within the scatter of the next).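

In this assay, within the data shown here, the earlier compounds changed only the group on an amine nitrogen in a ring, and all their steps stayed within the scatter. Placing 1,3-thiazol-4-yl in place of phenyl on a saturated chain carbon bound to an oxygen on a saturated carbon gives a 7.3-fold lower number from compound 2 to compound 4 (0.86 log units; beyond the scatter) and is the only step shown that lies beyond the scatter, so this second position can move the number more than any exchange seen on the amine nitrogen, although that rests on a single pair. Nothing in the data accounts for the size of this step.

Going by these compounds, whether the exchange gives a similar step with 3-chlorophenyl or 2,4-difluorophenyl on the amine nitrogen stays open. Also open, on these data alone, is how a pyridine ring or an oxazole ring would behave at this same place.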